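Fluoro to Bromo Swap on Two Related Cores

The source may report more compounds than this note shows. Statements on the series, on what has been measured and on what is new or still open speak of the compounds shown alone.

Measured in an assay on isolated protein for inhibition of Amine oxidase [flavin-containing] A (Homo sapiens), read by Amplex Red, with a stated time of 15 min, tested at 100 uM; a lower number here means less inhibition, a higher number more inhibition at the concentration tested (going by the name of the read-out):
compound 1 `CC(=O)c1ccc(OCc2cccc(F)c2)cc1` gives 48.4%;
compound 2 `CC(=O)c1ccc(OCc2cccc(Br)c2)cc1` gives 48.3%;
compound 3 `CC(=O)c1cccc(OCc2cccc(F)c2)c1` gives 31%.

Compound 1 and compound 2 share a core and differ by one change, (bromo in place of fluoro on an aromatic carbon), which produced the step of a number 0.1 percentage points lower from compound 1 to compound 2 (within the scatter). Compound 3 has the same atoms as compound 1 joined differently; the difference between the two cores is not broken down here. In this assay compound 3 stands lowest of the three, beyond the scatter from both others.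

Compound 4 `CC(=O)c1cccc(OCc2cccc(Br)c2)c1` has not yet been measured. It differs from compound 3 by bromo in place of fluoro on an aromatic carbon, the same change as between compound 1 and compound 2. Because the step of a number 0.1 percentage points lower from compound 1 to compound 2 (within the scatter) lay within the scatter, compound 4 is expected to sit close to compound 3, an expected step of no change at the digits printed from compound 3 to compound 4 (within the scatter). The estimate for compound 4 is 31%, expected between 19% and 43%.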

Compound 4, a percentage reported as inhibition, at one concentration (the size of the read-out at that concentration, not a potency): 49.1%
Beside the measured number, compound 4's estimate is 18.1 percentage points below it; measured number outside the range, above it.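

On the core of compound 3, the swap of fluoro for bromo gave a number 18.1 percentage points higher from compound 3 to compound 4 (beyond the scatter). In this assay the change therefore did not carry from one core to the other: the same change on two cores in this assay, a number 0.1 percentage points lower (within the scatter) from compound 1 to compound 2 and a number 18.1 percentage points higher (beyond the scatter) from compound 3 to compound 4, 18.2 percentage points apart, beyond the scatter of two such steps. This shows that the outcome of the swap depended on the core in these two pairs, but with one pair per core, at a single tested concentration, it does not show why the cores differ or what the swap would do on any further core.

The compounds shown leave open whether chloro or methoxy on the same aromatic carbon would follow fluoro or bromo on each core. They also leave open whether an amine in place of the halogen would show the same dependence on the core.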